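From compound 3 to a hydroxymethyl analogue

This account rests on a few compounds, and the source may have more. Where it says the series, first, only, none or still open, it means among the compounds named here.

Measured so far in a functional assay on HCT-116 cells (Homo sapiens) for inhibition, read by MTT assay, with a stated time of 72 h; on this read-out lower numbers stand for stronger inhibition and higher numbers for weaker inhibition:
Compound 1 `COc1cc(Oc2cccc(Nc3ccccc3)c2)cc(OC)c1CNCc1ccccc1` gives 4070 nM
Compound 2 `COc1cc(Oc2cccc(Nc3ccccc3)c2)cc(OC)c1CNCc1ccc(F)cc1` gives 4220 nM
Compound 3 `COc1ccc(CCCNCc2c(OC)cc(Oc3cccc(Nc4ccccc4)c3)cc2OC)cc1` gives 2850 nM

Compound 3 stands with the other two compounds and not apart from them. The steps are a 1.4-fold lower number from compound 1 to compound 3 (0.15 log units; within the scatter) and a 1.5-fold lower number from compound 2 to compound 3 (0.17 log units; within the scatter), and the remaining one is a 1.0-fold higher number from compound 1 to compound 2 (0.02 log units; within the scatter).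

The unmeasured compound 4 `COc1cc(Oc2cccc(Nc3ccccc3)c2)cc(OC)c1CCO` differs from compound 3 at one place: hydroxymethyl in place of (3-(4-methoxyphenyl)propyl)amino on a saturated chain carbon bound to an aromatic carbon. It carries hydroxymethyl in place of (3-(4-methoxyphenyl)propyl)amino on a saturated chain carbon bound to an aromatic carbon.

All three measured steps only exchange what the amine nitrogen carries, so none of them tests its loss. Every measured compound keeps that amine and a terminal aromatic ring, whereas compound 4 has neither. A higher number than compound 3 at 2850 nM is therefore expected, beyond the scatter, though this is a judgement and not a measured trend. The expected step is a 4.9-fold higher number from compound 3 to compound 4 (0.69 log units; beyond the scatter) in this assay. The estimate for compound 4 is 14000 nM, within an expected range from 4500 nM to 50000 nM.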

Compound 4, half-maximal inhibitory concentration: > 20000 nM
Compound 4 gave a limit, no number; the forecaster's own chance of this, stated with the estimate: 30%; middle value at least 1.4-fold (0.15 log units) from the limit.
By their numbers in this assay, from the lowest: compounds 3, 1 and 2 (each within the scatter of the next). At a limit, above all of these: compound 4.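

In this assay compound 4 gives only a limit and not a number: the limit of > 20000 nM in this assay, at which 1 of the 4 values shown sits. Exchanges of what the amine nitrogen carries had stayed within the scatter, but hydroxymethyl in place of the whole amino group is the first change at this saturated chain carbon to go beyond it, with an at least 7.0-fold higher number from compound 3 to compound 4 (0.84 log units; beyond the scatter) and an at least 4.7-fold higher number from compound 2 to compound 4 (0.67 log units; beyond the scatter) and also an at least 4.9-fold higher number from compound 1 to compound 4 (0.69 log units; beyond the scatter) in the same direction. The three compounds with a substituted amine therefore sit apart from compound 4, which has lost both the amine nitrogen and the terminal aromatic ring in a single change.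

Which of these two losses matters remains open. A plain primary amino group on that carbon would keep the nitrogen without the ring, and a benzyloxy group in place of benzylamino would keep the ring without the nitrogen.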